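Swapping Phenyl for Thiophene on a Sulfamoyl-Bearing Amine

A few compounds are considered here, and "the series" means these few. Any claim that something is new, unique, unknown or untested is made for them only; others in the source may bear on it.

Measured so far:
Compound 1 `c1ccc(CNc2nc(Nc3ccccc3)nc3ccccc23)cc1` gives 410 nM in a physicochemical assay for solubility, using the shake flask method, in phosphate buffer, measured as thermodynamic solubility, with stated times of 1 h and 6 h, at pH 7.4; a higher number here means a more soluble compound, a lower number a less soluble compound.
Compound 2 `NS(=O)(=O)c1cccc(Nc2nc(NCc3ccccc3)c3ccccc3n2)c1` gives 1370 nM in this assay.

Compound 2 holds the higher of the two numbers. Going by the values given here, its only neighbour is compound 1, and the difference between them is a 3.3-fold higher number from compound 1 to compound 2 (0.52 log units; beyond the scatter), the change being sulfamoyl in place of hydrogen on an aromatic carbon.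

Compound 3 `NS(=O)(=O)c1cccc(Nc2nc(NCc3cccs3)c3ccccc3n2)c1` has not yet been measured in this assay. It differs from compound 2 by thiophen-2-yl in place of phenyl on a saturated chain carbon bound to a nitrogen on an aromatic ring. Among the compounds with values here, the single measured step concerns a different part of the shared core, so no measured step bears on this change, and nothing in the data says whether a five-membered ring with one hetero atom in place of a six-membered ring of carbon only moves the number up or down.

Within the data shown here, with no guiding step, the expectation is a change within the usual scatter, estimated as a 1.1-fold lower number from compound 2 to compound 3 (0.06 log units; within the scatter) in this assay. Compound 3 is therefore estimated at 1200 nM, with a range from 450 nM to 3200 nM.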

Compound 3, solubility: 340 nM
Estimate against measurement, compound 3: 3.5-fold (0.55 log units) above, and the stated range ends above it.
By their numbers in this assay, from the lowest: compounds 3 and 1 (each within the scatter of the next); then compound 2.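

In this assay, going by these compounds alone, the earlier compounds showed only what the sulfamoyl change does, and compound 3 gives the first reading at a second place: on a saturated chain carbon bound to a nitrogen on an aromatic ring. Replacing phenyl, a six-membered aromatic ring of carbon only, with thiophen-2-yl, a five-membered aromatic ring with 1 hetero atom, gives a 4.0-fold lower number from compound 2 to compound 3 (0.61 log units; beyond the scatter) and so shows that an exchange of one aromatic ring for another at this place can move the number beyond the scatter, even with no net charge on either group. No measurement available here explains the direction or the size of this step.

A single exchange cannot show whether the lower number belongs to thiophen-2-yl in particular or would follow other departures from phenyl, such as furan-2-yl, cyclohexyl or a longer chain in place of benzyl. It also leaves open whether the same exchange would give a step of similar size on compound 1, which carries no sulfamoyl group.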